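A few compounds are considered here, and "the series" means these few. Any claim that something is new, unique, unknown or untested is made for them only; others in the source may bear on it.

Of the compounds shown here, two have been tested in a functional assay on the whole organism (strain CD1) with Mus musculus as the target, in the maximal electroshock model, with a stated time of 0.5 h; a lower number here means that less compound is needed, a higher number that more compound is needed for the effect. Compound 1, `CC1CC(=O)N(CC(=O)N2CCN(c3ccc(F)cc3)CC2)C1=O`, gives 300 mg/kg. Compound 2, `CC1CC(=O)N(CC(=O)N2CCN(c3cccc(C(F)(F)F)c3)CC2)C1=O`, gives 100 mg/kg. Compound 2 therefore stands at the lower of the two numbers, so less of it is needed, and its gap to compound 1 lies beyond the usual scatter of repeated measurements.

Compound 3, `CC1CC(=O)N(CC(=O)N2CCN(c3cccc(Cl)c3)CC2)C1=O`, has not yet been measured. It differs from compound 2 in one place: chloro in place of trifluoromethyl on an aromatic carbon. Both groups sit on the same aromatic carbon of the six-membered aromatic ring of carbon only, meta to a large group, and neither carries a hydrogen-bond donor or acceptor or a net charge.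

Among the measured compounds shown here, no step between two measured compounds that differ in exactly this way is available, so the expectation rests only on the fact that compound 2 already gives the lower number. The step from compound 2 to compound 3 is expected to be small, a 1.3-fold higher number from compound 2 to compound 3 (0.11 log units; within the scatter), and not clearly beyond the scatter in either direction. Compound 3 is accordingly estimated to give 130 mg/kg in this assay, with a range from 50 mg/kg to 300 mg/kg.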

Compound 3, minimum effective dose: 100 mg/kg
Estimate against measurement, compound 3: 1.3-fold (0.11 log units) above; low and high end bracket the measured number.
By their numbers in this assay, from the lowest: compounds 2 and 3 (each within the scatter of the next); then compound 1.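

In this assay, chloro in place of trifluoromethyl on this aromatic carbon gives no change at the digits printed from compound 2 to compound 3 (within the scatter), so here a group of 1 heavy atom serves as well as one of 4 heavy atoms, and the result does not depend on keeping trifluoromethyl. The second step, a 3.0-fold lower number from compound 1 to compound 3 (0.48 log units; beyond the scatter), shows that a chloro compound also stands clearly apart from the 4-fluorophenyl compound, although this single swap changes both the halogen and where it sits on the ring. Nothing measured here explains why chloro and trifluoromethyl give matching numbers, or why the 3-chlorophenyl group differs from the 4-fluorophenyl group.

The compounds shown leave open whether the gap to compound 1 follows the halogen or its place on the ring, a question that a 3-fluorophenyl or a 4-chlorophenyl group would help to separate. As far as these compounds go, it also remains open how an amine, a carboxylic acid or a methoxy group on this same aromatic carbon would compare with chloro and trifluoromethyl.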